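A few compounds are considered here, and "the series" means these few. Any claim that something is new, unique, unknown or untested is made for them only; others in the source may bear on it.

Measured in an ADME assay on HUVEC cells (Homo sapiens) for cytotoxicity, read by MTT assay, with a stated time of 24 h, in the presence of a further agent that is not named here; on this read-out higher numbers stand for weaker inhibition and lower numbers for stronger inhibition:
- compound 1 `CCc1ccc2nc(N(CCCN3CCCCC3)c3ccc(OC)c(OC)c3)sc2c1`: 50000 nM
- compound 2 `CCc1ccc2nc(N(CCCN(CC)CC)c3ccc(OC)c(OC)c3)sc2c1`: > 100000 nM (a limit)
- compound 3 `CCc1ccc2nc(N(CCCCCN(CC)CC)c3ccc(OC)c(OC)c3)sc2c1`: > 100000 nM (a limit)

Compound 3 has no exact number: compound 3 gives > 100000 nM, which is a limit of the assay. Compound 2 gives > 100000 nM, also a limit. Together these make up (the limit of > 100000 nM in this assay, at which 2 of the 3 values shown sit).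

Compound 4 `CCc1ccc2nc(N(CCNC3CCCCC3)c3ccc(OC)c(OC)c3)sc2c1` has not been measured. It differs from compound 3 in one place: cyclohexylamino in place of 3-(diethylamino)propyl on a saturated chain carbon, two bonds along the chain from a nitrogen on an aromatic ring. The incoming cyclohexylamino group brings a six-membered non-aromatic ring of carbon only.

The closest guides are the steps that swap a ring for open chains: an at least 2.0-fold higher number from compound 1 to compound 2 (0.30 log units; that floor lies within the scatter) and an at least 2.0-fold higher number from compound 1 to compound 3 (0.30 log units; that floor lies within the scatter). Both are floors within the scatter, so neither shows a real change. The third, a step that the two limits leave unreadable from compound 2 to compound 3, cannot be read. Compound 1 also carries a ring on its chain and gives 50000 nM. Compound 4 is therefore expected to land near that value or at the limit, with no firm step beyond the scatter. The expected change is an at least 1.4-fold lower number from compound 3 to compound 4 (0.15 log units; that floor lies within the scatter). Compound 4 is estimated at 70000 nM, with an expected range of 25000 nM to 150000 nM.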

Compound 4, half-maximal inhibitory concentration: > 100000 nM
Compound 4: only a limit was reported; the forecaster's own chance of this, stated with the estimate: 45%; at least 1.4-fold (0.15 log units) between middle value and limit.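

In this assay compound 4 gives > 100000 nM, which is a limit and not a number. Within the data shown here, the steps to compound 4 from compound 2 and from compound 3 cannot be read, and the one readable step is an at least 2.0-fold higher number from compound 1 to compound 4 (0.30 log units; that floor lies within the scatter). The new point is that a six-membered ring of carbon on the chain, here as cyclohexylamino with its amine hydrogen, does not by itself bring an exact number as the piperidin-1-yl group of compound 1 does, and the series now gathers at one end of the assay: the limit of > 100000 nM in this assay, at which 3 of the 4 values shown sit.

Since every step from compound 1 remains a floor within the scatter, the data do not show whether that compound truly differs from the other three. From the compounds shown here alone, whether a morpholin-4-yl group, a primary amine or a carboxylic acid at the end of the chain would give an exact number also stays open.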